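Hydrazone aryl swap on two related piperidine cores

The source may report more compounds than this note shows. Statements on the series, on what has been measured and on what is new or still open speak of the compounds shown alone.

Measured compounds, all in a functional assay on HT-29 cells (Homo sapiens) for cytotoxicity, read by MTT assay, with a stated time of 72 h; on this read-out lower numbers stand for stronger inhibition and higher numbers for weaker inhibition:
Compound 1, `COc1cc2c(Oc3ccc(NC(=O)N/N=C/c4ccc(C(F)(F)F)cc4)cc3F)ccnc2cc1OCCCN1CCCCC1`, gives 660 nM.
Compound 2, `COc1cc2c(Oc3ccc(NC(=O)N/N=C/c4ccc(Cl)cc4Cl)cc3F)ccnc2cc1OCCCN1CCCCC1`, gives 370 nM.
Compound 3, `COc1cc2c(Oc3ccc(NC(=O)N/N=C/c4ccc(C(F)(F)F)cc4)cc3F)ccnc2cc1OCCCN1CCC(C)CC1`, gives 740 nM.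

Compound 1 and compound 2 share one core and differ by 2,4-dichlorophenyl in place of 4-(trifluoromethyl)phenyl on a carbon with a double bond to nitrogen. The step is a 1.8-fold lower number from compound 1 to compound 2 (0.25 log units; within the scatter), so the two values sit close together. Compound 3 carries a different core, set apart from that of compound 1 by methyl in place of hydrogen on a saturated ring carbon; the step is a 1.1-fold higher number from compound 1 to compound 3 (0.05 log units; within the scatter), and compound 3 and compound 1 likewise sit close together. Within the data shown here, no step between compound 2 and compound 3 is broken down here; their values simply show that compound 2 and compound 3 lie within the usual spread of each other.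

Compound 4, `COc1cc2c(Oc3ccc(NC(=O)N/N=C/c4ccc(Cl)cc4Cl)cc3F)ccnc2cc1OCCCN1CCC(C)CC1`, has not been measured. It is set apart from compound 3 by 2,4-dichlorophenyl in place of 4-(trifluoromethyl)phenyl on a carbon with a double bond to nitrogen, which is the same change as that from compound 1 to compound 2, made on the other core. Compound 4 is therefore expected to follow compound 3 in the way compound 2 follows compound 1, with an estimated step of a 1.8-fold lower number from compound 3 to compound 4 (0.26 log units; within the scatter) in this assay, resting on a 1.8-fold lower number from compound 1 to compound 2 (0.25 log units; within the scatter) and on the value of compound 3, 740 nM. Compound 4 is estimated at 410 nM, expected to lie between 200 nM and 850 nM.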

Compound 4, half-maximal inhibitory concentration: 470 nM
Estimate against measurement, compound 4: 1.1-fold (0.06 log units) below, and the stated range covers the measured number.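

In this assay, the swap to 2,4-dichlorophenyl on the methyl-bearing core gives a 1.6-fold lower number from compound 3 to compound 4 (0.20 log units; within the scatter), and this step agrees with the one seen for the same swap on the core of compound 1: the same change on two cores in this assay, a 1.8-fold lower number (0.25 log units; within the scatter) from compound 1 to compound 2 and a 1.6-fold lower number (0.20 log units; within the scatter) from compound 3 to compound 4, 1.1-fold (0.05 log units) apart, within the scatter of two such steps The methyl on the saturated ring carbon, read with 2,4-dichlorophenyl in place, gives a 1.3-fold higher number from compound 2 to compound 4 (0.10 log units; within the scatter), and this step likewise agrees with the one read with 4-(trifluoromethyl)phenyl in place: the same change on two cores in this assay, a 1.1-fold higher number (0.05 log units; within the scatter) from compound 1 to compound 3 and a 1.3-fold higher number (0.10 log units; within the scatter) from compound 2 to compound 4, 1.1-fold (0.05 log units) apart, within the scatter of two such steps Across these four compounds, each change therefore carries from one core to the other without a detectable difference, but every step lies within the scatter, so the agreement shows neither that either change has a real effect on this read-out nor that it would carry to any further core.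

The compounds shown leave open whether a larger step would appear with a nitrile or a carboxylic acid on the aromatic ring in place of the two chlorines, or with a longer chain in place of the methyl on the saturated ring. They also leave open whether a basic amine other than the two shown at the end of the propyl chain would fit the same picture.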